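Working notes: fluoro on compound 2

The source may report more compounds than this note shows. Statements on the series, on what has been measured and on what is new or still open speak of the compounds shown alone.

Measured so far:
- compound 1 `C=C1CC(CBr)(c2ccc(F)cc2)OC1=O`: 1680 nM
- compound 2 `C=C1CC(CI)(c2ccccc2)OC1=O`: 1980 nM

In a functional assay on A549 cells (Homo sapiens) for antiproliferative activity, read by sulforhodamine B assay, with a stated time of 72 h (a higher number here means a weaker inhibitor, a lower number a stronger inhibitor), compound 2 gives 1980 nM, which lies within the scatter of compound 1 at 1680 nM. Compound 3 `C=C1CC(CI)(c2ccc(F)cc2)OC1=O` is not yet measured and differs from compound 2 by fluoro in place of hydrogen on an aromatic carbon. Within the data shown here, no measured pair isolates this change. No step beyond the scatter is expected in this assay. The expected change is a 1.1-fold lower number from compound 2 to compound 3 (0.04 log units; within the scatter). The estimate for compound 3 is 1800 nM, with an expected range from 900 nM to 3500 nM.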

Compound 3, half-maximal inhibitory concentration: 1210 nM
Beside the measured number, compound 3's estimate is 1.5-fold (0.17 log units) above it; low and high end bracket the measured number.
By their numbers in this assay, from the lowest: compounds 3, 1 and 2 (each within the scatter of the next).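

In this assay, among these compounds, the first pair to isolate fluoro in place of hydrogen on an aromatic carbon gives a 1.6-fold lower number from compound 2 to compound 3 (0.21 log units; within the scatter) and so shows that this position accepts fluoro with no step beyond the scatter. The second pair isolates iodo in place of bromo on the saturated chain carbon and gives a 1.4-fold lower number from compound 1 to compound 3 (0.14 log units; within the scatter), which also stays within the scatter. Nothing available bears on the origin of either step.

Going by these compounds, whether an amine or a carboxylic acid at the same ring position would stay within the scatter remains open. The same applies to chloro or a hydroxyl group on the chain carbon.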